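Compound 2 to Compound 3: Replacing the Ethynyl Group

A few compounds are considered here, and "the series" means these few. Any claim that something is new, unique, unknown or untested is made for them only; others in the source may bear on it.

compound 1 `C/C(=C\CC/C(C)=C/CC[C@@H]1[C@@]2(C)CCC(=O)C(C)(C)[C@H]2CC[C@@]1(C)O)CC/C=C(\C)C(=O)OCc1cn(C[C@@H]2O[C@H](n3ccc(=O)[nH]c3=O)C[C@H]2O)nn1`: 34100 nM
compound 2 `C#CCOC(=O)/C(C)=C/CC/C(C)=C/CC/C(C)=C/CC[C@@H]1[C@@]2(C)CCC(=O)C(C)(C)[C@H]2CC[C@@]1(C)O`: 27400 nM

Both values come from a functional assay on HT-29 cells (Homo sapiens) for antiproliferative activity, read by MTT assay, with a stated time of 48 h; on this read-out lower numbers stand for stronger inhibition and higher numbers for weaker inhibition. In this assay, compound 2 gives 27400 nM, which lies within the usual scatter of the value for compound 1, so the two compounds cannot be ranked.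

Compound 3 `C/C(=C\CC/C(C)=C/CC[C@@H]1[C@@]2(C)CCC(=O)C(C)(C)[C@H]2CC[C@@]1(C)O)CC/C=C(\C)C(=O)OCc1cn(-c2cccc(O)c2)nn1` has not yet been measured in this assay. It differs from compound 2 in one place: 1-(3-hydroxyphenyl)-1H-1,2,3-triazol-4-yl in place of ethynyl on a saturated chain carbon bound to an oxygen next to a carbonyl group. In words, 1-(3-hydroxyphenyl)-1H-1,2,3-triazol-4-yl stands in place of ethynyl on a saturated chain carbon bound to an oxygen next to a carbonyl group.

Going by the values given here, no measured step shows what this exchange does, so the expectation has little to rest on. Among the compounds with values here, the only guide is the narrow spread of the two known values, with compound 1 at 34100 nM. On that basis, no step beyond the scatter is expected in this assay, in either direction. The expected change is small: a 1.1-fold lower number from compound 2 to compound 3 (0.04 log units; within the scatter). For compound 3, the estimated value is 25000 nM, with an expected range from 10000 nM to 60000 nM.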

Compound 3, half-maximal inhibitory concentration: 38600 nM
Estimate against measurement, compound 3: 1.5-fold (0.19 log units) below, and the stated range covers the measured number.
By their numbers in this assay, from the lowest: compounds 2, 1 and 3 (each within the scatter of the next).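

In this assay, going by these compounds alone, the exchange of ethynyl for 1-(3-hydroxyphenyl)-1H-1,2,3-triazol-4-yl gives a 1.4-fold higher number from compound 2 to compound 3 (0.15 log units; within the scatter) and is the first step that can be read at this position. It shows that a small carbon-only group can give way to a much larger one, with a five-membered aromatic ring, a six-membered aromatic ring of carbon only, a hydrogen-bond donor and hydrogen-bond acceptors, and the read-out cannot be told apart from that of compound 2. Nothing available here bears on why this exchange leaves the read-out within the scatter.

On these data alone, this single step cannot separate the part played by the triazole from that of the hydroxyphenyl, so it remains open what a plain phenyl or a 3-aminophenyl on the same triazole would give. As far as these compounds go, it also remains open whether a group at this place can move the read-out beyond the scatter in either direction, for instance a carboxylic acid or a longer alkyl chain in place of ethynyl.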